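The source may report more compounds than this note shows. Statements on the series, on what has been measured and on what is new or still open speak of the compounds shown alone.

Working notes on the aryl-triazole urea series in a functional assay on HepG2 cells (Homo sapiens) for inhibition, read by MTT assay, with a stated time of 72 h; on this read-out higher numbers stand for weaker inhibition and lower numbers for stronger inhibition. Three compounds have numbers. Compound 1 `COc1cccc(-n2cc(COc3cccc(NC(=O)Nc4ccc(Cl)c(C(F)(F)F)c4)c3)nn2)c1` gives 1310 nM. Compound 2 `COc1ccc(-n2cc(COc3cccc(NC(=O)Nc4ccc(Cl)c(C(F)(F)F)c4)c3)nn2)cc1` gives 4680 nM, which is a 3.6-fold higher number from compound 1 to compound 2 (0.55 log units; beyond the scatter). Compound 3 `CCc1ccccc1-n1cc(COc2cccc(NC(=O)Nc3ccc(Cl)c(C(F)(F)F)c3)c2)nn1` gives 3530 nM, the second highest of the three numbers; against compound 1 this is a 2.7-fold higher number from compound 1 to compound 3 (0.43 log units; beyond the scatter), whereas the gap a 1.3-fold lower number from compound 2 to compound 3 (0.12 log units; within the scatter) is within the scatter, so compound 2 and compound 3 cannot be told apart on these numbers.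

Compound 4 `O=C(Nc1cccc(OCc2cn(-c3ccccc3Cl)nn2)c1)Nc1ccc(Cl)c(C(F)(F)F)c1` is not yet measured. Relative to compound 3 the difference is chloro in place of ethyl on an aromatic carbon, the ethyl leaving and chloro entering, the same difference read one bond further out being 2-ethylphenyl to 2-chlorophenyl. Among the compounds with values here, no measured step bears directly on this change: the steps known move the methoxy around the ring or swap it for ethyl, and none swaps one group for another on the same aromatic carbon ortho to a large group. The two steps that touch that carbon, a 2.7-fold higher number from compound 1 to compound 3 (0.43 log units; beyond the scatter) and a 1.3-fold lower number from compound 2 to compound 3 (0.12 log units; within the scatter), were modest or within the scatter, which gives no ground to expect a large move.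

Compound 4 is therefore expected near compound 3, estimated at 3200 nM with a range of 1200 nM to 8500 nM; the expected step is a 1.1-fold lower number from compound 3 to compound 4 (0.04 log units; within the scatter), not beyond the scatter.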

Compound 4, half-maximal inhibitory concentration: 1960 nM
Compound 4: the middle estimate sits 1.6-fold (0.21 log units) above what was measured; the measured number falls inside the stated range.
By their numbers in this assay, from the lowest: compounds 1, 4, 3 and 2 (each within the scatter of the next, the first and the last beyond it).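

In this assay, within the data shown here, the first swap on this aromatic carbon ortho to a large group, chloro in place of ethyl, does not resolve from the scatter (a 1.8-fold lower number from compound 3 to compound 4 (0.26 log units; within the scatter)), so on these numbers the two groups cannot be told apart at this place. The comparison with the other aryl groups does shift: 2-chlorophenyl cannot be told apart from 3-methoxyphenyl (a 1.5-fold higher number from compound 1 to compound 4 (0.17 log units; within the scatter)) but separates from 4-methoxyphenyl (a 2.4-fold lower number from compound 2 to compound 4 (0.38 log units; beyond the scatter)), the reverse of what 2-ethylphenyl showed in compound 3, although that shift rests on a step within the scatter. No measurement here accounts for this difference between the two groups at this place.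

Still open, from the compounds shown here alone, is whether any group on this carbon moves the number beyond the scatter relative to ethyl or chloro, for instance a methoxy, an amine, a carboxylic acid or a longer chain. Also open is whether chloro placed elsewhere on this ring would follow the difference seen between compound 1 and compound 2, since the only comparison of ring placement shown is for methoxy.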